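The compounds below may be only part of what the source reports. "The series", "measured", "known", "first", "only" and "open" are said of these compounds alone.

Among the measured compounds shown here, in a functional assay on HepG2 cells (Homo sapiens) for cytotoxicity, with a stated time of 24 h (on this read-out lower numbers stand for stronger inhibition and higher numbers for weaker inhibition), compound 2 `COc1ccc(Cl)cc1C(=S)Nc1cc(Cl)ccc1O` gives 8600 nM, the highest number of the three measured so far. Compound 1 `COc1cc(Cl)ccc1C(=S)Nc1ccc(Br)cc1O` gives 3880 nM and compound 3 `COc1ccc(Cl)cc1C(=S)Nc1cc(Cl)c(Cl)cc1O` gives 3720 nM, both lower than compound 2 beyond the scatter. Compound 4 `COc1ccc(Cl)cc1C(=S)Nc1cc(C(F)(F)F)ccc1O` is not yet measured and differs from compound 2 as follows: trifluoromethyl in place of chloro on an aromatic carbon. For the measured compounds named here, the only measured step that bears on this is a 2.3-fold lower number from compound 2 to compound 3 (0.36 log units; beyond the scatter), a modest change with chloro in place of hydrogen on an aromatic carbon. Going by the values given here, no measured step tests trifluoromethyl directly, so a small shift towards a lower number is expected in this assay, no larger than that step. The expected step is a 1.6-fold lower number from compound 2 to compound 4 (0.19 log units; within the scatter). For compound 4 the estimated value is 5500 nM, with an expected range of 2500 nM to 12000 nM.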

Compound 4, half-maximal inhibitory concentration: 5860 nM
Compound 4: the middle estimate sits 1.1-fold (0.03 log units) below what was measured; measured number inside the range.
By their numbers in this assay, from the lowest: compounds 3, 1, 4 and 2 (each within the scatter of the next, the first and the last beyond it).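

In this assay trifluoromethyl in place of chloro, para to a hydroxy group, gives a 1.5-fold lower number from compound 2 to compound 4 (0.17 log units; within the scatter) and so this position takes four heavy atoms in place of one without a shift beyond the scatter. The earlier step, chloro in place of hydrogen, lay on another aromatic carbon and did not test any exchange at this position. Going by these compounds, whether an amine or a carboxylic acid here would also stay within the scatter of compound 2 remains open. Nothing available gives a cause for this result.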